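Replacing an aryl ring with a hexyl chain in a diacylhydrazine

The source may hold more compounds than are shown below. What is called first, only, known or untested is meant among the compounds shown, and "the series" means these compounds.

Measured compounds:
compound 1 `CC(C)(C)N(NC(=O)c1ccccc1)C(=O)c1ccccc1I` gives 105 nM in an assay on cells for agonist activity at ecdysone receptor (Bombyx mori), read by a luciferase reporter, with a stated time of 24 h; on this read-out lower numbers stand for an effect already at smaller amounts and higher numbers for an effect only at larger amounts of compound
compound 2 `COc1ccc(C(=O)NN(C(=O)c2ccccc2Cl)C(C)(C)C)cc1` gives 51.3 nM in this assay
compound 3 `Cc1ccc(C(=O)NN(C(=O)c2cc(C)cc(C)c2)C(C)(C)C)cc1` gives 12 nM in this assay

Among these three, compound 1 has the highest number, so it needs the largest amount for a half-maximal effect; its gaps to compound 2 and compound 3 both lie beyond the scatter. Compound 4 `CCCCCCC(=O)N(NC(=O)c1ccccc1)C(C)(C)C` is not yet measured. It differs from compound 1 in one place: hexyl in place of 2-iodophenyl on a carbonyl carbon. Among the compounds with values here, no pair of measured compounds shows a change of this kind, so its effect cannot be read from the data. For compound 4 a step from compound 1 in the direction of a higher number is expected, a 24-fold higher number from compound 1 to compound 4 (1.38 log units; beyond the scatter). Compound 4 is estimated at 2500 nM, within 300 nM to 20000 nM.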

Compound 4, half-maximal effective concentration: 7240 nM
Compound 4: middle estimate off by 2.9-fold (0.46 log units), on the low side; low and high end bracket the measured number.
By their numbers in this assay, from the lowest: compound 3; then compound 2; then compound 1; then compound 4.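

In this assay, the swap of hexyl for 2-iodophenyl on a carbonyl carbon gives a 69-fold higher number from compound 1 to compound 4 (1.84 log units; beyond the scatter), the first measured sign that this position responds strongly to the group it carries. The change removes the aromatic ring and the iodine together, so the step cannot be divided between them. No measurement shown here explains the step.

As far as these compounds go, whether the ring, the iodine or both matter stays open. A plain phenyl or a cyclohexyl ring in this place would help to separate them.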